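A Single Methyl Group and an Open Measurement

This account rests on a few compounds, and the source may have more. Where it says the series, first, only, none or still open, it means among the compounds named here.

- Compound 1 `COc1ccc2nc(NC(=O)CCCCC(=O)NO)sc2c1` gives 5.91 ug/mL in a functional assay on MCF7 cells (Homo sapiens) for cytotoxicity; on this read-out lower numbers stand for stronger inhibition and higher numbers for weaker inhibition
- Compound 2 `O=C(CCCCCCC(=O)Nc1nc2ccccc2s1)NO` gives 6.61 ug/mL in this assay

For the measured compounds named here, only these two compounds have numbers so far. Their values lie within the scatter of each other, so compound 2 stands level with compound 1 and the two cannot be ranked. The compound now awaiting measurement is compound 3 `Cc1ccc2nc(NC(=O)CCCCCCC(=O)NO)sc2c1` which differs from compound 2 in one place. The difference methyl in place of hydrogen on an aromatic carbon amounts to methyl in place of hydrogen on an aromatic carbon of a six-membered aromatic ring of carbon only. Going by the values given here, no measured pair in this small set differs in just one place, so the data offer no direct precedent for this change. The expectation therefore rests on compound 2 at 6.61 ug/mL as its anchor, with no direction favoured. The step of a 1.0-fold lower number from compound 2 to compound 3 (0.01 log units; within the scatter) is expected to stay within the scatter of this assay and not to go beyond it. As far as these compounds go, for compound 3 the estimated value is 6.5 ug/mL with an expected range from 3.2 ug/mL to 13 ug/mL while the measurement remains open.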

Compound 3, half-maximal inhibitory concentration: 1.6 ug/mL
Beside the measured number, compound 3's estimate is 4.1-fold (0.61 log units) above it; the whole stated range lies above it.
By their numbers in this assay, from the lowest: compound 3; then compounds 1 and 2 (each within the scatter of the next).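

In this assay, for the compounds shown here, compounds 2 and 3 form the first pair in this set that differs in just one place, and it shows that the aromatic carbon carrying the change is not a silent position. Methyl in place of hydrogen there gives a 4.1-fold lower number from compound 2 to compound 3 (0.62 log units; beyond the scatter) and so counts as a modest but real gain in inhibition, which the earlier compounds could not show because none of them formed such a pair. The entering group is small, with one carbon, no ring, no hydrogen-bond donors or acceptors and no net charge, yet that is enough to move the number past the scatter in this pair, and nothing available accounts for the step, so its cause remains unknown.

Going by these compounds alone, the single pair leaves open whether the gain is particular to methyl or would also appear with an ethyl group, a chlorine atom or an amine on the same aromatic carbon. It also leaves open whether the methyl would bring a similar step on a longer chain, or at another carbon of the same ring.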